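Propyl in Place of Phenyl on the Shared Core

A few compounds are considered here, and "the series" means these few. Any claim that something is new, unique, unknown or untested is made for them only; others in the source may bear on it.

Compound 1 `CCc1nnc([S+]([O-])Cc2ncc(C)c(OC)c2C)o1` gives 10000 nM in a functional assay on HUVEC cells (Homo sapiens) for inhibition, read by ELISA; a lower number here means a stronger inhibitor, a higher number a weaker inhibitor.
Compound 2 `COc1c(C)cnc(C[S+]([O-])c2nnc(-c3ccccc3)o2)c1C` gives 6000 nM in this assay.
Compound 3 `[O-][S+](Cc1ccccc1)c1nnc(-c2ccccc2O)o1` gives 6000 nM in this assay.

Compound 2 stands level with compound 3 at the digits shown, the two together the lowest of the three numbers, while compound 1 lies within the scatter of both. Compound 4 `CCCc1nnc([S+]([O-])Cc2ncc(C)c(OC)c2C)o1` differs from compound 2 in one place: propyl in place of phenyl on an aromatic carbon. Among the compounds with values here, the only measured step that bears on this is a 1.7-fold lower number from compound 1 to compound 2 (0.22 log units; within the scatter), itself within the scatter. Compound 4 undoes that exchange and carries a plain chain like the ethyl of compound 1, so no step beyond the scatter is expected in this assay, and compound 4 is expected to land near compound 1. The estimate for compound 4 is 8000 nM, between 3000 nM and 20000 nM, an expected step of a 1.3-fold higher number from compound 2 to compound 4 (0.12 log units; within the scatter).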

Compound 4, half-maximal inhibitory concentration: 8000 nM
Estimate against measurement, compound 4: no gap at the digits printed, within the range that was stated.
By their numbers in this assay, from the lowest: compounds 2, 3, 4 and 1 (each within the scatter of the next).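

Replacing phenyl with propyl on this aromatic carbon gives a 1.3-fold higher number from compound 2 to compound 4 (0.12 log units; within the scatter) in this assay, and adding a methyl to the ethyl chain gives a 1.3-fold lower number from compound 1 to compound 4 (0.10 log units; within the scatter) as the chain becomes propyl. With these steps, ethyl, propyl and phenyl at this position all lie within the scatter of one another, so neither the ring nor this extra chain carbon separates compounds 1, 2 and 4 here. No measurement at hand offers a reason for this. Going by these compounds, it remains open whether an amine, a carboxylic acid or a much longer chain at this position would move the number beyond the scatter.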